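From amide to urea on a shared core

The compounds below may be only part of what the source reports. "The series", "measured", "known", "first", "only" and "open" are said of these compounds alone.

In a functional assay on MDA-MB-435 cells (Homo sapiens) for inhibition, read by sulforhodamine B assay, with a stated time of 48 h (on this read-out lower numbers stand for stronger inhibition of growth and higher numbers for weaker inhibition of growth), compound 1 `COc1cc(-c2nn(-c3cccc(NC(=O)c4cccc(C(F)(F)F)c4)c3)cc2-c2ccncc2)ccc1Cl` gives 1770 nM, and compound 2 `O=C(Nc1cccc(-n2cc(-c3ccncc3)c(-c3ccc(Cl)c(O)c3)n2)c1)Nc1cc(C(F)(F)F)cc(C(F)(F)F)c1` gives 2590 nM; the two numbers sit within the scatter of each other, so neither compound can be ranked above the other. Compound 3 `COc1cc(-c2nn(-c3cccc(NC(=O)Nc4ccc(Cl)c(C(F)(F)F)c4)c3)cc2-c2ccncc2)ccc1Cl` differs from compound 1 by (4-chloro-3-(trifluoromethyl)phenyl)amino in place of 3-(trifluoromethyl)phenyl on a carbonyl carbon, turning the amide into a urea. Among the measured compounds shown here, no step between measured compounds isolates this change, and compound 2 carries its urea on a different core. For compound 3 the expected step is a 1.2-fold lower number from compound 1 to compound 3 (0.07 log units; within the scatter), no larger than the scatter. Compound 3 is estimated at 1500 nM, with a range from 500 nM to 4500 nM.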

Compound 3, concentration for total growth inhibition: 1690 nM
The estimate for compound 3 lay 1.1-fold (0.05 log units) below the measured number, and the stated range covers the measured number.
By their numbers in this assay, from the lowest: compounds 3, 1 and 2 (each within the scatter of the next).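

In this assay, the step that turns the amide into a urea and brings in (4-chloro-3-(trifluoromethyl)phenyl)amino on the carbonyl carbon reads as a 1.0-fold lower number from compound 1 to compound 3 (0.02 log units; within the scatter) and so leaves the number on the shared core within the scatter. Among the compounds shown here, this is the first direct reading of the change on one core, which compound 2, with its different core, could not give. Nothing measured here offers an explanation for this result.

On these data alone, the urea nitrogen and the chlorine enter together in this one step, so what each does alone stays open. Also open, as far as these compounds go, is how a saturated amine such as morpholine would read on this carbonyl carbon.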